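A few compounds are considered here, and "the series" means these few. Any claim that something is new, unique, unknown or untested is made for them only; others in the source may bear on it.

Compound 1 `O=S(=O)(NCCCNc1nccc(-c2c(-c3cccc(F)c3)nc3sccn23)n1)c1cccc(F)c1` gives 8550 nM in a functional assay on SK-MEL-28 cells (Homo sapiens) for cytotoxicity, read by MTT assay; a lower number here means a stronger inhibitor, a higher number a weaker inhibitor.
Compound 2 `O=S(=O)(NCCCNc1nccc(-c2c(-c3cccc(F)c3)nc3sccn23)n1)c1ccc(Br)cc1` gives 9400 nM in this assay.
Compound 3 `O=S(=O)(NCCNc1nccc(-c2c(-c3cccc(F)c3)nc3sccn23)n1)c1ccc(Br)cc1` gives 13500 nM in this assay.

All three numbers sit close together. Compound 2 stands second highest of the three, and both of its neighbours lie within the usual scatter: a 1.1-fold higher number from compound 1 to compound 2 (0.04 log units; within the scatter) and a 1.4-fold higher number from compound 2 to compound 3 (0.16 log units; within the scatter). The shared core of these compounds is the same throughout; only the sulfonyl-bearing ring and the length of the chain vary, and neither variation moves the number beyond the scatter.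

Compound 4 `O=C(NCCCNc1nccc(-c2c(-c3cccc(F)c3)nc3sccn23)n1)c1ccc(F)cc1` has not yet been measured. Compared with compound 2 it carries the change ((4-fluorophenyl)carbonyl in place of (4-bromophenyl)sulfonyl on an amine nitrogen). Within the data shown here, one measured step bears on part of this change: a 1.1-fold higher number from compound 1 to compound 2 (0.04 log units; within the scatter) swaps the ring on the sulfonyl sulfur and stays within the scatter. Among the measured compounds shown here, no measured step replaces a sulfonyl with a carbonyl, so that part of the change has no precedent here. The expectation is therefore a step of no clear direction, a 1.1-fold higher number from compound 2 to compound 4 (0.03 log units; within the scatter), with wide uncertainty. Compound 4 is estimated at 10000 nM in this assay, expected to fall between 3500 nM and 30000 nM.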

Compound 4, half-maximal inhibitory concentration: > 20000 nM
Compound 4 gave a limit, no number (the forecaster's own chance of this, stated with the estimate: 10%); middle value at least 2.0-fold (0.30 log units) from the limit.
By their numbers in this assay, from the lowest: compounds 1, 2 and 3 (each within the scatter of the next). At a limit, above all of these: compound 4.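

Compound 4 gave a limit and not a number in this assay: the limit of > 20000 nM in this assay, at which 1 of the 4 values shown sits.

Among these compounds, at the amine nitrogen, the move from a sulfonyl to a carbonyl group brings the first steps in this set that pass the scatter, an at least 2.1-fold higher number from compound 2 to compound 4 (0.32 log units; beyond the scatter) and an at least 2.3-fold higher number from compound 1 to compound 4 (0.36 log units; beyond the scatter), so the higher number points to a weaker inhibitor, whereas swapping the ring on the sulfonyl sulfur had stayed within the scatter. The remaining step, an at least 1.4-fold higher number from compound 3 to compound 4 (0.17 log units; that floor lies within the scatter), has a floor within the scatter and does not separate these two compounds.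

The change also swaps the ring, so the compounds shown cannot say how much belongs to the carbonyl alone, and a 4-bromophenyl carbonyl would test that. From the compounds shown here alone, how a plain methylene amine or a urea would behave at this nitrogen stays open.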